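Adding a second chloro to compound 3

The source may hold more compounds than are shown below. What is called first, only, known or untested is meant among the compounds shown, and "the series" means these compounds.

In a functional assay on SGC-7901 cells (Homo sapiens) for antiproliferative activity, read by MTT assay, with a stated time of 48 h (on this read-out lower numbers stand for an effect already at smaller amounts and higher numbers for an effect only at larger amounts of compound), compound 1 `CC1=NN(S(=O)(=O)c2ccccc2)C(c2cc(Br)ccc2O)C1` gives 55600 nM and compound 2 `CC1=NN(S(=O)(=O)c2ccccc2C)C(c2cc(Br)ccc2O)C1` gives 48100 nM.

Compound 3 `CC1=NN(S(=O)(=O)c2ccc(Cl)cc2)C(c2cc(Br)ccc2O)C1` gives > 60000 nM, which is a limit of the assay and not a number. It stands at the limit of > 60000 nM in this assay, at which 1 of the 3 values shown sits.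

Compound 4 `CC1=NN(S(=O)(=O)c2ccc(Cl)cc2Cl)C(c2cc(Br)ccc2O)C1` turns the 4-chlorophenyl of compound 3 into 2,4-dichlorophenyl: chloro in place of hydrogen on an aromatic carbon. The new chloro replaces a hydrogen on an aromatic carbon, ortho to a large group.

Going by the values given here, two measured steps bear on this change. A methyl placed on an aromatic carbon gave a 1.2-fold lower number from compound 1 to compound 2 (0.06 log units; within the scatter), and a chloro placed on an aromatic carbon gave an at least 1.0-fold higher number from compound 1 to compound 3 (0.03 log units; that floor lies within the scatter). Neither step shows a change beyond the scatter, so no step beyond the scatter is expected in this assay, in either direction. The expected step is an at least 1.2-fold lower number from compound 3 to compound 4 (0.07 log units; that floor lies within the scatter). A further limit would not be a surprise. For compound 4 the estimated value is 50000 nM, with an expected range from 22000 nM to 90000 nM.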

Compound 4, half-maximal effective concentration: > 60000 nM
Compound 4 was reported as a limit (the forecaster's own chance of this, stated with the estimate: 45%); middle value at least 1.2-fold (0.07 log units) from the limit.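

In this assay, compound 4 gives a limit of the assay and not a number, as compound 3 does, so the step between them cannot be read, and adding this chloro ortho to a large group yields no size of effect. Set against the two compounds that have numbers, the result is an at least 1.2-fold higher number from compound 2 to compound 4 (0.09 log units; that floor lies within the scatter) and an at least 1.0-fold higher number from compound 1 to compound 4 (0.03 log units; that floor lies within the scatter), so neither comparison separates the compounds. What the new result does add is that a second compound now sits at the same limit: the limit of > 60000 nM in this assay, at which 2 of the 4 values shown sit.

Going by these compounds, whether this chloro changes the activity at all therefore stays open. Also open, on these data alone, is whether an amine, a carboxylic acid or a methoxy group on the same aromatic carbon would give a readable number.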